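Aryl swap on the ring nitrogen of the thiazolidinone series

The source may report more compounds than this note shows. Statements on the series, on what has been measured and on what is new or still open speak of the compounds shown alone.

Measured compounds:
- compound 1 `COc1ccc(C)cc1N1C(=O)CSC1c1cccc(C(=O)NCCCCc2ccccc2)c1`: 95%
- compound 2 `COc1ccc(OC)c(N2C(=O)CSC2c2cccc(C(=O)NCCCCc3ccccc3)c2)c1`: 20%
- compound 3 `CC(F)(F)c1cccc(N2C(=O)CSC2c2cccc(C(=O)NCCCCc3ccccc3)c2)c1`: 93%

In a functional assay on HOS-TE85 cells (Homo sapiens) for inhibition, read by CCK-8 assay, with a stated time of 72 h, tested at 1 uM (a higher number here means more inhibition at the concentration tested (going by the name of the read-out), a lower number less inhibition), compound 1 gives 95%, the highest of the three numbers. Compound 3 sits within the scatter of it, the step being a number 2 percentage points lower from compound 1 to compound 3 (within the scatter). Compound 2 lies far off: a number 75 percentage points lower from compound 1 to compound 2 (beyond the scatter), and the return a number 73 percentage points higher from compound 2 to compound 3 (beyond the scatter) is equally large. Every measured step exchanges the aryl group on the amide-type nitrogen in the ring, so all three bear on the next compound.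

Compound 4 `COc1c(F)cccc1N1C(=O)CSC1c1cccc(C(=O)NCCCCc2ccccc2)c1` is not yet measured. Relative to compound 1 the change is 3-fluoro-2-methoxyphenyl in place of 2-methoxy-5-methylphenyl on an amide-type nitrogen in a ring. Compound 4 keeps the methoxy of compound 1 but trades the methyl for a fluorine in another position. Compound 2 shows that a change on this ring can cost most of the inhibition, while compound 3 shows another aryl losing nothing. A new substitution pattern on the ring is therefore expected to carry real risk but no clear sign of either outcome.

Compound 4 is estimated at 70%, expected range 30% to 95%, a step of a number 25 percentage points lower from compound 1 to compound 4 (beyond the scatter).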

Compound 4, a percentage reported as inhibition, at one concentration (the size of the read-out at that concentration, not a potency): 12%
Estimate against measurement, compound 4: 58 percentage points above, outside the stated range (below it).
By their numbers in this assay, from the lowest: compounds 4 and 2 (each within the scatter of the next); then compounds 3 and 1 (each within the scatter of the next).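

In this assay, 3-fluoro-2-methoxyphenyl on the amide-type nitrogen collapses the inhibition, both against 2-methoxy-5-methylphenyl (a number 83 percentage points lower from compound 1 to compound 4 (beyond the scatter)) and against the aryl of compound 3 (a number 81 percentage points lower from compound 3 to compound 4 (beyond the scatter)). The result does not separate from the 2,5-dimethoxyphenyl compound (a number 8 percentage points lower from compound 2 to compound 4 (within the scatter)), so the low level of compound 2 is no longer a single case and does not need a second methoxy. The methoxy shared with compound 1 is also not enough to hold the inhibition: compound 4 and compound 2 both carry a methoxy and read low, while compound 3 carries none and reads high, which goes against any reading of methoxy as either sufficient or required.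

Compound 4 changes two things on the aryl at once, and the compounds shown do not separate the effect of adding the fluorine from that of losing the methyl, nor tell how a chlorine or an amine in place of that fluorine would read. No measurement at hand gives a cause for the drop.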